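Compound 2 Leads Two Values Before Compound 3

The source may report more compounds than this note shows. Statements on the series, on what has been measured and on what is new or still open speak of the compounds shown alone.

Compound 1 `Cc1ccc(N(C(=O)c2ccc(F)cc2F)C(=S)OCCN2C(=O)c3ccccc3C2=O)cc1` - 20000 nM
Compound 2 `Cc1ccc(N(C(=O)c2cc(F)cc(F)c2)C(=S)OCCN2C(=O)c3ccccc3C2=O)cc1` - 54000 nM

Going by the values given here, in an ADME assay on MT4 cells (Homo sapiens) for cytotoxicity, read by MTT assay (on this read-out higher numbers stand for lower toxicity in this test and lower numbers for higher toxicity in this test), compound 2 holds the higher of the two numbers, with compound 1 the only comparison. Compound 3 `Cc1ccc(N(C(=O)c2ccc(Cl)c([N+](=O)[O-])c2)C(=S)OCCN2C(=O)c3ccccc3C2=O)cc1` differs from compound 2 as follows: 4-chloro-3-nitrophenyl in place of 3,5-difluorophenyl on a carbonyl carbon. This puts 4-chloro-3-nitrophenyl in place of 3,5-difluorophenyl on a carbonyl carbon. Among the compounds with values here, only one measured step bears on this change, a 2.7-fold higher number from compound 1 to compound 2 (0.43 log units; beyond the scatter), and it was modest. It exchanged one difluorophenyl group for another, so it is only a loose guide to the new group. A modest move to a lower number is expected, with the direction uncertain, and the expected change is a 2.2-fold lower number from compound 2 to compound 3 (0.33 log units; beyond the scatter). Compound 3 is estimated at 25000 nM, within a range of 8000 nM to 70000 nM.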

Compound 3, half-maximal cytotoxic concentration: 47000 nM
The estimate for compound 3 lay 1.9-fold (0.27 log units) below the measured number; measured number inside the range.
By their numbers in this assay, from the lowest: compound 1; then compounds 3 and 2 (each within the scatter of the next).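

In this assay the exchange on the carbonyl carbon gives a 1.1-fold lower number from compound 2 to compound 3 (0.06 log units; within the scatter) and so leaves 4-chloro-3-nitrophenyl and 3,5-difluorophenyl indistinguishable, although the two groups share only their carbon ring. The exchange for 2,4-difluorophenyl gives a 2.4-fold higher number from compound 1 to compound 3 (0.37 log units; beyond the scatter) and so sets compound 1 apart from both other compounds. No measurement offered here accounts for either result.

Still open, going by these compounds, is whether an amine or a carboxylic acid on this phenyl ring would keep the number in this range. Also open, on these data alone, is whether a saturated cyclohexyl group in place of the phenyl ring would do so.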